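This account rests on a few compounds, and the source may have more. Where it says the series, first, only, none or still open, it means among the compounds named here.

In an ADME assay on L1210 cells (Mus musculus) for cytotoxicity, with a stated time of 48 h (a lower number here means a stronger inhibitor, a higher number a weaker inhibitor), compound 3 (`CC1=CCC[C@](C)(CC/C(C)=C/CC2=C(O)C(=O)C=C(N[C@@H](CO)C(=O)O)C2=O)[C@@H]1C`) stands at > 10 ug/mL and that is a limit, not a number. Compound 1 (`CC1=CCC[C@](C)(CC/C(C)=C/CC2=C(O)C(=O)C=C(N[C@H](C(=O)O)[C@@H](C)O)C2=O)[C@@H]1C`) gives > 10 ug/mL and that is also a limit. On these data alone, these two make up the limit of > 10 ug/mL in this assay, at which 2 of the 3 values shown sit, and the true position of compound 3 remains unknown. For the measured compounds named here, compound 2 (`C=C1[C@H](C)CCC[C@]1(C)CC/C(C)=C/CC1=C(O)C(=O)C=C(N[C@H](CO)C(=O)O)C1=O`) gives 2.6 ug/mL and is the only compound here with a number.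

Compound 4 (`CC1=CCC[C@](C)(CC/C(C)=C/CC2=C(O)C(=O)C=C(N[C@H](CO)C(=O)O)C2=O)[C@@H]1C`) has not yet been measured. The structural difference is the two compounds have the same atoms and bonds and differ only in configuration as drawn: 1 of 4 stereo elements differ; a stereocentre at a saturated chain carbon is drawn S in compound 3 and R in compound 4 and no atom or bond changes. Going by the values given here, the one measured step involving compound 3 is a step that the two limits leave unreadable from compound 1 to compound 3 and it concerns a different change, so it offers no size to carry over. Among the compounds with values here, no measured step tests this configuration. In this assay no clear shift is therefore expected, and a further limit is the likeliest report. The expected move is a number no higher from compound 3 to compound 4 (the limit leaves the size open) as a rough estimate with no firm direction. For compound 4 the estimate is 10 ug/mL with an expected range of 4 ug/mL to 20 ug/mL as a wide band.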

Compound 4, half-maximal inhibitory concentration: > 10 ug/mL
Compound 4 gave a limit, no number; the forecaster's own chance of this, stated with the estimate: 60%; the middle value sits exactly at the limit.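

In this assay, for the compounds shown here, the exchange of one group of nine carbons, with its six-membered non-aromatic ring of carbon only, for the other gives an at least 3.8-fold higher number from compound 2 to compound 4 (0.58 log units; beyond the scatter), the one readable step so far. This gives the ring group a measured link to the read-out, with the amino acid end as drawn held fixed. At the saturated chain carbon, neither drawn configuration yields a number, and the steps from compound 3 and compound 1 to compound 4 cannot be read, so the size of any configuration effect stays unknown: the limit of > 10 ug/mL in this assay, at which 3 of the 4 values shown sit.

On these data alone, how far compound 3 and compound 4 lie beyond the limit remains open, as does whether the configuration matters with the ring group of compound 2. As far as these compounds go, the effect of a methyl ester in place of the carboxylic acid also remains open.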